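Swapping the carbamate tail for a hexyl urea

A few compounds are considered here, and "the series" means these few. Any claim that something is new, unique, unknown or untested is made for them only; others in the source may bear on it.

In a functional assay on WI-38 VA13 cells (Homo sapiens) for cytotoxicity (a higher number here means that more compound is needed for the effect, a lower number that less compound is needed), compound 1 `CCCC(=O)Nc1nc2ccc(NC(=O)c3c(Cl)cccc3Cl)cc2s1` gives 0.01 ug/mL and compound 3 `COCCOC(=O)Nc1nc2ccc(NC(=O)c3c(Cl)cccc3Cl)cc2s1` gives 0.011 ug/mL. The two sit together on this assay, since a 1.1-fold higher number from compound 1 to compound 3 (0.04 log units; within the scatter). Compound 2 `O=C(O)CCC(=O)Nc1nc2ccc(NC(=O)c3c(Cl)cccc3Cl)cc2s1` shows only a limit, > 6.6 ug/mL, which is the limit of > 6.6 ug/mL in this assay, at which 1 of the 3 values shown sits. The steps of an at least 660-fold higher number from compound 1 to compound 2 (2.81 log units; beyond the scatter) and an at least 600-fold lower number from compound 2 to compound 3 (2.77 log units; beyond the scatter) set the carboxy chain apart. Compound 4 `CCCCCCNC(=O)Nc1nc2ccc(NC(=O)c3c(Cl)cccc3Cl)cc2s1` changes compound 3 by hexylamino in place of 2-methoxyethoxy on a carbonyl carbon. Of the measured steps, only the exchange of one uncharged tail for another bears on it, and that step lay within the scatter, so no step beyond the scatter is expected here, a 1.1-fold higher number from compound 3 to compound 4 (0.04 log units; within the scatter). Compound 4 is therefore estimated at 0.012 ug/mL, within 0.004 ug/mL to 0.04 ug/mL.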

Compound 4, half-maximal effective concentration: 0.29 ug/mL
Beside the measured number, compound 4's estimate is 24-fold (1.38 log units) below it; measured number outside the range, above it.
By their numbers in this assay, from the lowest: compounds 1 and 3 (each within the scatter of the next); then compound 4. At a limit, above all of these: compound 2.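

So the tail on this carbonyl carbon is not interchangeable among uncharged groups: in this assay, hexylamino brings a 26-fold higher number from compound 3 to compound 4 (1.42 log units; beyond the scatter), and likewise a 29-fold higher number from compound 1 to compound 4 (1.46 log units; beyond the scatter). Compound 4 still lies well short of the carboxy chain, with an at least 22-fold lower number from compound 2 to compound 4 (1.35 log units; beyond the scatter). That step rests on a limit, not a number: the limit of > 6.6 ug/mL in this assay, at which 1 of the 4 values shown sits.

The compounds shown cannot separate the effect of the nitrogen from that of the hexyl chain. A hexyloxy or heptyl tail, or a shorter methylamino tail, on the same carbonyl carbon would pull the two apart.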